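This account rests on a few compounds, and the source may have more. Where it says the series, first, only, none or still open, it means among the compounds named here.

Compound 1 `COc1ccc(C2=C(c3cc(OC)c(OC)c(OC)c3)C(=O)C(O)C2)cc1NC(=O)c1ccccc1`, in an ADME assay on HEp-2 cells (Homo sapiens) for cytotoxicity, read by MTT assay, with a stated time of 72 h (a higher number here means a weaker inhibitor, a lower number a stronger inhibitor), a limit of > 100 ug/mL.
Compound 2 `COc1ccc(C2=C(c3cc(OC)c(OC)c(OC)c3)C(=O)C(O)C2)cc1`, in this assay a limit of < 1 ug/mL.

Compound 2 sits at the limit of < 1 ug/mL in this assay, at which 1 of the 2 values shown sits, so its value is a limit of the assay and not a number. Compound 1 sits at the limit of > 100 ug/mL in this assay, at which 1 of the 2 values shown sits, likewise a limit. Among the compounds with values here, the single measured step, an at least 100-fold lower number from compound 1 to compound 2 (2.00 log units; beyond the scatter), is therefore known only as a lower bound on its size. Compound 3 `COc1ccc(C2=C(c3cc(OC)c(OC)c(OC)c3)C(=O)C(O)C2)cc1OC(C)C` differs from compound 2 by isopropoxy in place of hydrogen on an aromatic carbon. The step from compound 1 to compound 2 bears on this change, because an at least 100-fold lower number from compound 1 to compound 2 (2.00 log units; beyond the scatter) concerns the same aromatic carbon, though there a benzamido group left rather than an isopropoxy group entering. An isopropoxy group is smaller and carries no hydrogen-bond donor, so the author expects a rise in the number for compound 3 that is smaller than that step, namely an at least 5.0-fold higher number from compound 2 to compound 3 (0.69 log units; beyond the scatter). Compound 3 is thus estimated at 5 ug/mL, in the range 1 ug/mL to 40 ug/mL.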

Compound 3, half-maximal inhibitory concentration: > 100 ug/mL
Compound 3 gave a limit, no number (the forecaster's own chance of this, stated with the estimate: 25%); at least 20-fold (1.30 log units) between middle value and limit.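

Compound 3 gives > 100 ug/mL in this assay, a limit of the assay and not a number. Isopropoxy in place of hydrogen on this aromatic carbon thus brings an at least 100-fold higher number from compound 2 to compound 3 (2.00 log units; beyond the scatter), a size known only as a lower bound. Until now only benzamido spoke for this carbon; a second group, with no ring and 0 hydrogen-bond donors, now also goes with a far higher number than compound 2 shows, so in these compounds neither a ring nor a hydrogen-bond donor in the group on this carbon is needed for that rise.

The step between compound 1 and compound 3 cannot be read, as both values are limits, so the two groups cannot be ranked. Also open, as far as these compounds go, is whether a small group on this carbon, such as an amine or a hydroxyl group, would keep the low number of compound 2.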